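The source may report more compounds than this note shows. Statements on the series, on what has been measured and on what is new or still open speak of the compounds shown alone.

Measured so far:
compound 1 `COc1ccc(C(c2ccc(OCCO)cc2)c2cccc3ccccc23)c(OC)c1OC` — > 20000 nM
compound 2 `COc1ccc(C(c2ccc(O)cc2)c2cccc3ccccc23)c(OC)c1OC` — 17400 nM

Among the measured compounds shown here, in a functional assay on MDA-MB-231 cells (Homo sapiens) for inhibition, read by sulforhodamine B assay, with a stated time of 48 h (a lower number here means a stronger inhibitor, a higher number a weaker inhibitor), compound 2 gives 17400 nM, the only plain number. For compound 1 the result is the limit > 20000 nM, as noted in the limit of > 20000 nM in this assay, at which 1 of the 2 values shown sits. For the measured compounds named here, the step of an at least 1.1-fold lower number from compound 1 to compound 2 (0.06 log units; that floor lies within the scatter) is the sole measured change at the oxygen on the aromatic ring, and it does not rise out of the scatter.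

Compound 3 `COc1ccc(C(c2ccc(OCC(=O)O)cc2)c2cccc3ccccc23)c(OC)c1OC` is the next member. Its difference from compound 2: carboxymethyl in place of hydrogen on an oxygen on an aromatic ring. Going by the values given here, the only measured step that bears on this change is an at least 1.1-fold lower number from compound 1 to compound 2 (0.06 log units; that floor lies within the scatter), where a substituent on that same oxygen gives way to hydrogen without a shift beyond the scatter. Placing carboxymethyl on that oxygen is therefore expected to bring no change beyond the scatter in this assay, the expected step being a 1.1-fold higher number from compound 2 to compound 3 (0.06 log units; within the scatter). Compound 3 is accordingly estimated at 20000 nM, with a range from 8000 nM to 50000 nM, and a real chance that only a limit is reported.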

Compound 3, half-maximal inhibitory concentration: > 20000 nM
Compound 3: only a limit was reported (the forecaster's own chance of this, stated with the estimate: 45%); the middle value lies on the limit itself.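

Carboxymethyl on the oxygen on the aromatic ring gives an at least 1.1-fold higher number from compound 2 to compound 3 (0.06 log units; that floor lies within the scatter) in this assay, so a second substituent at this position, now one ending in a carboxylic acid, also yields no step that rises out of the scatter. Compound 1 and compound 3 both carry only limits, and the step between them cannot be read, so hydroxymethyl and carboxy at the chain end cannot be ranked. Most of the series now gives no plain number, which leaves little room for comparison at this oxygen: the limit of > 20000 nM in this assay, at which 2 of the 3 values shown sit.

How far the true values of compound 1 and compound 3 lie from compound 2 remains open, so a real loss on substitution is neither shown nor excluded. Also open, going by these compounds, is whether an amine at the chain end, or a longer chain on this oxygen, would give a plain number.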